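The source may hold more compounds than are shown below. What is called first, only, known or untested is meant among the compounds shown, and "the series" means these compounds.

Compound 1 `CCOC(=O)Nc1ccc(S(=O)(=O)N2C[C@H](c3ccccc3)NC2=O)cc1C` gives 50 nM in a functional assay on A549 cells (Homo sapiens) for cytotoxicity, read by MTT assay (a higher number here means a weaker inhibitor, a lower number a stronger inhibitor), the higher of the two numbers obtained in the series. Compound 3 `CCOC(=O)Nc1ccc(S(=O)(=O)N2C[C@H](c3ccccc3)NC2=O)cc1Cl` gives 20 nM in this assay. Compound 2 `CCOC(=O)Nc1c(C)cc(S(=O)(=O)N2C[C@H](c3ccccc3)NC2=O)cc1C` sits at a limit of this assay, > 10000 nM. One of the three values shown sits at the limit of > 10000 nM in this assay, at which 1 of the 3 values shown sits. The step of an at least 200-fold higher number from compound 1 to compound 2 (2.30 log units; beyond the scatter) and the step of a 2.5-fold lower number from compound 1 to compound 3 (0.40 log units; beyond the scatter) are both changes on the aromatic ring. Compound 4 `CCOC(=O)Nc1ccc(S(=O)(=O)N2C(=O)N[C@@H](c3ccccc3)C2C)cc1C` differs from compound 1 by methyl in place of hydrogen on a saturated ring carbon. Neither measured step touches a saturated ring carbon, so no step beyond the scatter is expected in this assay, though the range is kept wide. For compound 4 the estimate is 80 nM, between 20 nM and 400 nM, expected as a step of a 1.6-fold higher number from compound 1 to compound 4 (0.20 log units; within the scatter).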

Compound 4, half-maximal inhibitory concentration: 5000 nM
For compound 4 the middle estimate is 63-fold (1.80 log units) below the measured one; measured number above the stated range.
By their numbers in this assay, from the lowest: compound 3; then compound 1; then compound 4. At a limit, above all of these: compound 2.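

Methyl in place of hydrogen on a saturated ring carbon brings a 100-fold higher number from compound 1 to compound 4 (2.00 log units; beyond the scatter) in this assay, so large steps are not confined to the aromatic ring. Methyl in place of hydrogen now gives a large step at both places shown, on an aromatic carbon and on this saturated ring carbon. Compound 2 remains the only compound at a limit: the limit of > 10000 nM in this assay, at which 1 of the 4 values shown sits.

As far as these compounds go, whether an ethyl, a hydroxyl or an amine at this saturated ring carbon would stay close to compound 1 remains open. These compounds give no cause for the step.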